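The source may hold more compounds than are shown below. What is called first, only, known or untested is meant among the compounds shown, and "the series" means these compounds.

Measured so far in a functional assay on HCC827 cells (Homo sapiens) for antiproliferative activity, read by MTT assay, with a stated time of 72 h; a higher number here means a weaker inhibitor, a lower number a stronger inhibitor:
- compound 1 `CN1CCN(c2ccc(Nc3ncc4nc(Nc5ccc(F)cc5)n([C@H]5CCCN(S(=O)(=O)C6CC6)C5)c4n3)cc2)CC1`: 8.6 nM
- compound 2 `CN1CCN(c2ccc(Nc3ncc4nc(Nc5ccc(F)cc5)n(CCNS(=O)(=O)C5CC5)c4n3)cc2)CC1`: 50 nM
- compound 3 `CNC(=O)CN1CC[C@H](n2c(Nc3ccc(F)cc3)nc3cnc(Nc4ccc(N5CCN(C)CC5)cc4)nc32)C1`: 1520 nM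

Compound 1 holds the lowest number of the three. The step to compound 2 is a 5.8-fold higher number from compound 1 to compound 2 (0.76 log units; beyond the scatter); the step to compound 3 is a 180-fold higher number from compound 1 to compound 3 (2.25 log units; beyond the scatter); between those two, a 30-fold higher number from compound 2 to compound 3 (1.48 log units; beyond the scatter).

Compound 4 `CN1CCN(c2ccc(Nc3ncc4nc(Nc5ccc(F)cc5)n([C@H]5CCN(S(=O)(=O)C6CC6)C5)c4n3)cc2)CC1` is not yet measured. It differs from compound 1 in one place: 1-(cyclopropylsulfonyl)pyrrolidin-3-yl in place of 1-(cyclopropylsulfonyl)piperidin-3-yl on an aromatic nitrogen. The substituent on the aromatic nitrogen keeps the cyclopropylsulfonyl cap and the saturated ring with one hetero atom, with the ring one member smaller.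

Among the compounds with values here, no measured step isolates this change. Compound 3 also carries a pyrrolidin-3-yl on that nitrogen, but with a different cap, so a 180-fold higher number from compound 1 to compound 3 (2.25 log units; beyond the scatter) cannot be read as a ring-size effect alone. Compound 2 shows that replacing the piperidine by an open chain costs a 5.8-fold higher number from compound 1 to compound 2 (0.76 log units; beyond the scatter), a modest step. Compound 4 is therefore expected to stay near compound 1, with at most a modest rise, a step of about a 1.7-fold higher number from compound 1 to compound 4 (0.24 log units; within the scatter). The estimate for compound 4 in this assay is 15 nM, within 5 nM to 60 nM.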

Compound 4, half-maximal inhibitory concentration: 7.5 nM
Beside the measured number, compound 4's estimate is 2.0-fold (0.30 log units) above it; low and high end bracket the measured number.
By their numbers in this assay, from the lowest: compounds 4 and 1 (each within the scatter of the next); then compound 2; then compound 3.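

In this assay, the ring-size change alone, 1-(cyclopropylsulfonyl)pyrrolidin-3-yl in place of 1-(cyclopropylsulfonyl)piperidin-3-yl, gives a 1.1-fold lower number from compound 1 to compound 4 (0.06 log units; within the scatter) and so makes no distinction between the two rings under the cyclopropylsulfonyl cap. With the five-membered ring held constant, the cap can now be read on its own: cyclopropylsulfonyl in place of (methylcarbamoyl)methyl gives a 200-fold lower number from compound 3 to compound 4 (2.31 log units; beyond the scatter) and 1-(cyclopropylsulfonyl)pyrrolidin-3-yl in place of the open 2-((cyclopropylsulfonyl)amino)ethyl chain gives a 6.7-fold lower number from compound 2 to compound 4 (0.82 log units; beyond the scatter) as a smaller step. No measurement shown accounts for these steps.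

Still open, as far as these compounds go, is whether a methanesulfonyl or acetyl cap on the pyrrolidine nitrogen would hold the number of compound 4. A four-membered azetidine ring under the cyclopropylsulfonyl cap also remains to be placed in this series.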